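Chain homologues on a shared core: extension to compound 4

The source may report more compounds than this note shows. Statements on the series, on what has been measured and on what is new or still open speak of the compounds shown alone.

Measured so far in a functional assay on L1210 cells (Mus musculus) for cytotoxicity; on this read-out higher numbers stand for an effect only at larger amounts of compound and lower numbers for an effect already at smaller amounts:
compound 1, `CCCC(O)C1=CC(=O)c2c(OC)ccc(OC)c2C1=O`, 0.409 ug/mL
compound 2, `CCC(O)C1=CC(=O)c2c(OC)ccc(OC)c2C1=O`, 0.516 ug/mL
compound 3, `CCCCC(O)C1=CC(=O)c2c(OC)ccc(OC)c2C1=O`, 0.412 ug/mL

Compound 3 sits second highest of the three numbers; its value lies within the scatter of compound 1 and of compound 2 alike, so the three cannot be ordered on these data. Compound 4, `CCCCCCCC(O)C1=CC(=O)c2c(OC)ccc(OC)c2C1=O`, is not yet measured. It differs from compound 3 by propyl in place of hydrogen on a saturated chain carbon, five bonds along the chain from a double-bonded ring carbon and an oxygen on a saturated carbon.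

Among the compounds with values here, the steps that bear on this are the earlier chain extensions on the same carbon: a 1.3-fold lower number from compound 2 to compound 3 (0.10 log units; within the scatter) and a 1.0-fold higher number from compound 1 to compound 3 (0.00 log units; within the scatter), and in the other direction a 1.3-fold higher number from compound 1 to compound 2 (0.10 log units; within the scatter). None of these moved this assay beyond the scatter. The change to compound 4 is larger than any of them, but nothing in the series shows chain length on this carbon mattering, so no step beyond the scatter is expected: a 1.1-fold higher number from compound 3 to compound 4 (0.04 log units; within the scatter). The estimate for compound 4 is 0.45 ug/mL, with a range from 0.18 ug/mL to 1.1 ug/mL. The range is set somewhat wide: the extension to compound 4 is longer than any step measured.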

Compound 4, concentration for half-maximal effect: 1.04 ug/mL
Compound 4: middle estimate off by 2.3-fold (0.36 log units), on the low side; the range from low to high includes it.
By their numbers in this assay, from the lowest: compounds 1, 3, 2 and 4 (each within the scatter of the next, the first and the last beyond it).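

In this assay, within the data shown here, this is the first extension on this carbon to go beyond the scatter: propyl in place of hydrogen, five bonds along the chain from a double-bonded ring carbon and an oxygen on a saturated carbon, gives a 2.5-fold higher number from compound 3 to compound 4 (0.40 log units; beyond the scatter), and the comparison with the shorter chain reads alike, a 2.5-fold higher number from compound 1 to compound 4 (0.41 log units; beyond the scatter). Chain length here therefore does register on this read-out once the chain is long enough, which the three shorter chains did not show. The shift is modest and does not separate compound 4 from every shorter chain: a 2.0-fold higher number from compound 2 to compound 4 (0.30 log units; within the scatter) stays within the scatter.

On these data alone, whether a longer chain would carry the shift further, or an amine on the chain would behave as the plain carbon chains do, remains open. No available evidence bears on what lies behind the shift.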